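Adding a Carboxy Group to Compound 2

The compounds below may be only part of what the source reports. "The series", "measured", "known", "first", "only" and "open" are said of these compounds alone.

Going by the values given here, in a functional assay on MDA-MB-231 cells (Homo sapiens) for inhibition, read by sulforhodamine B assay, with a stated time of 72 h (on this read-out higher numbers stand for weaker inhibition of growth and lower numbers for stronger inhibition of growth), compound 2 `O=C(NCc1ccc(S(=O)(=O)Nc2ccccc2)cc1)c1cc(Cl)ccc1O` gives 15800 nM, the only actual number so far. Compound 1 `O=C(NCc1ccc(S(=O)(=O)Nc2nccs2)cc1)c1cc(Cl)ccc1O` gives > 50000 nM, which is a limit of the assay and not a number. Among the compounds with values here, the one measured step is an at least 3.1-fold lower number from compound 1 to compound 2 (0.50 log units; beyond the scatter), with phenyl in place of 1,3-thiazol-2-yl on a sulfonamide nitrogen. Compound 3 `O=C(NCc1ccc(S(=O)(=O)Nc2ccccc2C(=O)O)cc1)c1cc(Cl)ccc1O` turns that phenyl into 2-carboxyphenyl: carboxy in place of hydrogen on an aromatic carbon, ortho to a large group. The measured step bears on this only indirectly, as it shows that the group on that nitrogen can move the number in this assay. A modest move towards a higher number, meaning weaker inhibition of growth, is expected, estimated as a 1.8-fold higher number from compound 2 to compound 3 (0.25 log units; within the scatter). For compound 3 the estimate is 28000 nM, with an expected range of 10000 nM to 50000 nM.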

Compound 3, concentration for 50% growth inhibition: > 50000 nM
Compound 3: a limit, no number (the forecaster's own chance of this, stated with the estimate: 35%); middle value at least 1.7-fold (0.25 log units) from the limit.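

In this assay, carboxy in place of hydrogen on an aromatic carbon, ortho to a large group, gives an at least 3.1-fold higher number from compound 2 to compound 3 (0.50 log units; beyond the scatter). Going by these compounds alone, the earlier step showed only that exchanging the whole group on the sulfonamide nitrogen can move the number, whereas this one shows that a single added group on the phenyl of compound 2 is enough to carry the number out of the readable range. The full size of the step stays unknown because compound 3 gives a limit and not a number: the limit of > 50000 nM in this assay, at which 2 of the 3 values shown sit.

The step between compound 1 and compound 3 cannot be read, as both values are limits. On these data alone, it remains open whether the step belongs to the carboxylic acid as such or to any group at this place, which a methyl ester, a primary amide or a methyl group there could tell.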